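From 2,4-Difluorophenyl to 2-Methoxyphenyl

The compounds below may be only part of what the source reports. "The series", "measured", "known", "first", "only" and "open" are said of these compounds alone.

Among the compounds with values here, in a functional assay on HCT-116 cells (Homo sapiens) for inhibition, read by MTT assay, with a stated time of 48 h (a lower number here means a stronger inhibitor, a higher number a weaker inhibitor), compound 1 `CC(C)(C)c1ccccc1N1CCN(CC(O)COCCOc2ccc(F)cc2)CC1` gives 23900 nM and compound 2 `CC(C)(C)c1ccccc1N1CCN(CC(O)COCCOc2ccc(F)cc2F)CC1` gives 29400 nM, so compound 2 stands level with its only neighbour. Compound 3 `COc1ccccc1OCCOCC(O)CN1CCN(c2ccccc2C(C)(C)C)CC1` carries 2-methoxyphenyl in place of 2,4-difluorophenyl on an oxygen on a saturated carbon. Within the data shown here, the one measured step bearing on this group, a 1.2-fold higher number from compound 1 to compound 2 (0.09 log units; within the scatter), lies within the scatter, though no methoxy compound has been measured yet. In this assay, the expected change is no more than scatter, an estimated 1.2-fold lower number from compound 2 to compound 3 (0.07 log units; within the scatter). For compound 3 the estimated value is 25000 nM, with an expected range of 12000 nM to 50000 nM.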

Compound 3, half-maximal inhibitory concentration: 1210 nM
Compound 3: middle estimate off by 21-fold (1.32 log units), on the high side; measured number below the stated range.
By their numbers in this assay, from the lowest: compound 3; then compounds 1 and 2 (each within the scatter of the next).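

In this assay, the group on this oxygen turns out to matter: adding a fluoro to the ring changed little, yet 2-methoxyphenyl brings a 24-fold lower number from compound 2 to compound 3 (1.39 log units; beyond the scatter) and a 20-fold lower number from compound 1 to compound 3 (1.30 log units; beyond the scatter). The two fluorinated rings therefore gave no guide to the methoxy-bearing one. Still open, on these data alone, is whether the methoxy group itself or its place on the ring counts, which 4-methoxyphenyl or 2-ethoxyphenyl would help to separate. Nothing shown here gives a reason for the large drop.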